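Moving the Phenol from the 3- to the 4-Position

The source may report more compounds than this note shows. Statements on the series, on what has been measured and on what is new or still open speak of the compounds shown alone.

Of the compounds shown here, three sharing one core have been measured in an assay on isolated protein for inhibition of DNA topoisomerase 1 (Homo sapiens), with a stated time of 30 min, tested at 100 uM; on this read-out higher numbers stand for a stronger effect at the one concentration tested and lower numbers for a weaker effect. Compound 1 `Oc1ccc(-c2cc(-c3cccs3)cc(-c3ccccc3O)n2)cc1` gives 72.2%, compound 2 `Oc1ccc(-c2cc(-c3ccoc3)cc(-c3ccccc3O)n2)cc1` gives 30.1%, and compound 3 `Oc1cccc(-c2cc(-c3ccccn3)cc(-c3ccccc3O)n2)c1` gives 35.4%. Compound 3 therefore stands second highest of the three numbers: its nearest neighbour is compound 2, lower by a margin within the scatter, while compound 1 lies beyond the scatter above it. Among the measured compounds shown here, the only measured step, a number 42.1 percentage points lower from compound 1 to compound 2 (beyond the scatter), concerns the exchange of the five-membered ring and was large.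

Compound 4 `Oc1ccc(-c2cc(-c3ccccn3)cc(-c3ccccc3O)n2)cc1` differs from compound 3 by 4-hydroxyphenyl in place of 3-hydroxyphenyl on an aromatic carbon. For the measured compounds named here, no measured step covers this particular exchange, so the expectation leans on the spread of the three values rather than on a direct precedent. Compound 4 is estimated to show a number 4.6 percentage points higher from compound 3 to compound 4 (within the scatter) in this assay, a step not expected to exceed the scatter. Compound 4 is thus expected to give 40%, with a likely range from 20% to 65%.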

Compound 4, a percentage reported as inhibition, at one concentration (the size of the read-out at that concentration, not a potency): 0.2%
Compound 4: middle estimate off by 39.8 percentage points, on the high side; measured number outside the range, below it.
By their numbers in this assay, from the lowest: compound 4; then compounds 2 and 3 (each within the scatter of the next); then compound 1.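

In this assay, the place of the hydroxyl on this phenyl ring, next to the ring nitrogen, proves decisive: a number 35.2 percentage points lower from compound 3 to compound 4 (beyond the scatter), although 3-hydroxyphenyl and 4-hydroxyphenyl have the same atoms and the same counts of donors and acceptors. With 4-hydroxyphenyl held in place, pyridin-2-yl also compares poorly with both five-membered rings, with a number 29.9 percentage points lower from compound 2 to compound 4 (beyond the scatter) and a number 72 percentage points lower from compound 1 to compound 4 (beyond the scatter), so the earlier thiophen-2-yl to furan-3-yl step no longer stands alone as evidence that this other ring position matters. Nothing available explains why either change has this size.

As far as these compounds go, it remains open whether the same shift of the hydroxyl would cost as much with thiophen-2-yl or furan-3-yl in the molecule. Also open, from the compounds shown here alone, is how an amine or a carboxylic acid would read in place of the hydroxyl on this ring.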